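Notes on the step from compound 2 to compound 3

A few compounds are considered here, and "the series" means these few. Any claim that something is new, unique, unknown or untested is made for them only; others in the source may bear on it.

Measured in an ADME assay on microsomes from liver (Homo sapiens) for metabolic stability; on this read-out lower numbers stand for slow clearance and higher numbers for fast clearance:
- compound 1 `CC(=O)N[C@@H]1CCC[C@H](C(=O)Nc2cc(-c3cnn4c3CCCC4)ccn2)C1`: < 3 mL.min-1.g-1 (a limit of the assay)
- compound 2 `CC(=O)N[C@@H]1CCC[C@H](C(=O)Nc2cc(-c3cnn4c3CCCC4)c(Cl)cn2)C1`: 17 mL.min-1.g-1

Going by the values given here, compound 2 holds the only true number so far, as the result for compound 1 is a limit. Compound 3 `CC(=O)N[C@@H]1CCC[C@H](C(=O)Nc2cc(-c3cnn(C)c3C)c(Cl)cn2)C1` keeps the chloro group and differs from compound 2 in one place: a group of 7 heavy atoms (5 carbon, 2 nitrogen; one five-membered aromatic ring with 2 hetero atoms) in place of a group of 9 heavy atoms (7 carbon, 2 nitrogen; one five-membered aromatic ring with 2 hetero atoms, one six-membered non-aromatic ring with 1 hetero atom), on an aromatic carbon. Among the compounds with values here, no measured step covers this exchange. Within the data shown here, the one measured step, chloro in place of hydrogen, gave an at least 5.6-fold higher number from compound 1 to compound 2 (0.75 log units; beyond the scatter), which is beyond the scatter. That step concerns the chloro group, which stays, so it gives no size for the new exchange. No shift beyond the scatter in this assay is therefore expected, and the estimated step is a 1.4-fold lower number from compound 2 to compound 3 (0.15 log units; within the scatter). The expected value for compound 3 is 12 mL.min-1.g-1, with an estimated range of 5 mL.min-1.g-1 to 30 mL.min-1.g-1.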

Compound 3, intrinsic clearance in microsomes: 3.3 mL.min-1.g-1
Compound 3: the middle estimate sits 3.6-fold (0.56 log units) above what was measured, outside the stated range (below it).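

In this assay, the exchange of the two-ring group for 1,5-dimethyl-1H-pyrazol-4-yl, on the aromatic carbon ortho to the chloro group, gives a 5.2-fold lower number from compound 2 to compound 3 (0.71 log units; beyond the scatter). Going by these compounds alone, the earlier step concerned only the chloro group, so this is the first sign that the group at this position also moves the read-out beyond the scatter, with the chloro group kept in place. Compound 1 holds the one limit in the series, and this limit restricts how far any further lower number could be read: the limit of < 3 mL.min-1.g-1 in this assay, at which 1 of the 3 values shown sits.

The compounds shown do not separate the loss of the six-membered non-aromatic ring from the presence of the two methyl groups, nor show whether the exchange gives a similar step without the chloro group. On these data alone, it also remains open how an ethyl group in place of either methyl, or an amine on the same five-membered aromatic ring, would read.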